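The source may report more compounds than this note shows. Statements on the series, on what has been measured and on what is new or still open speak of the compounds shown alone.

Values measured in a functional assay on MCF7 cells (Homo sapiens) for antiproliferative activity, read by MTT assay, with a stated time of 48 h; a higher number here means a weaker inhibitor, a lower number a stronger inhibitor:
- compound 1 `CC(C)=CCC[C@]1(C)/C=C/[C@@H](OC(=O)C=C(C)C)[C@](C)(O)/C=C/C(=O)/C(C(=O)O)=C\C1` gives 16100 nM
- compound 2 `CCN(CC)C/C1=C/C[C@](C)(CCC=C(C)C)/C=C/[C@@H](OC(=O)C=C(C)C)[C@](C)(O)/C=C/C1=O` gives 130 nM
- compound 3 `CC(C)=CCC[C@]1(C)/C=C/[C@@H](OC(=O)C=C(C)C)[C@](C)(O)/C=C/C(=O)/C(CN2CCCC2)=C\C1` gives 220 nM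

Compound 3 stands close to compound 2 and far from compound 1 . Putting (diethylamino)methyl in place of carboxy gave a large step, a 120-fold lower number from compound 1 to compound 2 (2.09 log units; beyond the scatter), and (pyrrolidin-1-yl)methyl in the same place gave another, a 73-fold lower number from compound 1 to compound 3 (1.86 log units; beyond the scatter). Exchanging diethylamino for pyrrolidin-1-yl gave only a 1.7-fold higher number from compound 2 to compound 3 (0.23 log units; within the scatter).

Compound 4 `CC(C)=CCC[C@]1(C)/C=C/[C@@H](OC(=O)C=C(C)C)[C@](C)(O)/C=C/C(=O)/C(CN2CCN(C)CC2)=C\C1` has 4-methylpiperazin-1-yl in place of pyrrolidin-1-yl on a saturated chain carbon bound to a double-bonded ring carbon. The carboxy group plays no part in this change, so the closest guide is the exchange with a 1.7-fold higher number from compound 2 to compound 3 (0.23 log units; within the scatter). Among the measured compounds shown here, that is a single example, and no measured compound carries the new group. No step beyond the scatter is therefore expected in this assay. The expected change is a 1.3-fold higher number from compound 3 to compound 4 (0.10 log units; within the scatter). For compound 4 the estimated value is 280 nM, with an expected range from 90 nM to 900 nM.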

Compound 4, half-maximal inhibitory concentration: 550 nM
The estimate for compound 4 lay 2.0-fold (0.29 log units) below the measured number; the measured number falls inside the stated range.
By their numbers in this assay, from the lowest: compounds 2 and 3 (each within the scatter of the next); then compound 4; then compound 1.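

In this assay, the choice of amine on this saturated chain carbon does make a difference: 4-methylpiperazin-1-yl gives a 2.5-fold higher number from compound 3 to compound 4 (0.40 log units; beyond the scatter) and a 4.2-fold higher number from compound 2 to compound 4 (0.63 log units; beyond the scatter), whereas diethylamino and pyrrolidin-1-yl could not be told apart. Even so, replacing carboxy with (4-methylpiperazin-1-yl)methyl still gives a 29-fold lower number from compound 1 to compound 4 (1.47 log units; beyond the scatter), so all three amines lie far on the stronger side of compound 1. No measurement is available to explain why compound 4 gives the higher number.

As far as these compounds go, it remains open whether this shift follows the second ring nitrogen, its methyl or the six-membered ring. Piperidin-1-yl, a six-membered ring without a second nitrogen, and piperazin-1-yl, which lacks the methyl, would help separate these three features.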